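Removing the Pyridinylamino Arm: Expected Distribution Volume

The compounds below may be only part of what the source reports. "The series", "measured", "known", "first", "only" and "open" are said of these compounds alone.

Measured compounds:
- compound 1, `CC(=O)Nc1cc(-c2c(Nc3ccn(C)n3)nc3ccccn23)nc(C)n1`, gives 0.6 L/kg in an in vivo ADME assay on the whole organism for pharmacokinetics, with Rattus norvegicus as the target, at a dose of 0.5 mg/kg by the intravenous route; a higher number here means that more of the compound sits outside the plasma, a lower number that more of the compound stays in the plasma
- compound 2, `Cc1nc(Nc2cccnc2)cc(-c2c(Nc3cc[nH]n3)nc3cccnn23)n1`, gives "not determined" (no result reported) in this assay

Compound 2 stands without a number in this assay; its entry reads as no result, so it offers no baseline of its own. The only figure in hand belongs to compound 1, whose 0.6 L/kg in this assay describes a compound that stays largely in the plasma rather than spreading into tissue.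

Compound 3, `Cc1nccc(-c2c(Nc3cc[nH]n3)nc3cccnn23)n1`, shares the core of compound 2 and differs from it in one place:

hydrogen in place of (pyridin-3-yl)amino on an aromatic carbon

Among the measured compounds shown here, no step between two measured compounds is available to size this change, so nothing can be said about how it has behaved before. The expectation for compound 3 in this assay is therefore a step no larger than the usual scatter, in no particular direction.

Since compound 1 gives 0.6 L/kg in this assay, compound 3 is expected to give about 0.8 L/kg, within a range from 0.3 L/kg to 2 L/kg.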

Compound 3, volume of distribution at steady state in the Rattus norvegicus assay: 0.62 L/kg
For compound 3 the middle estimate is 1.3-fold (0.11 log units) above the measured one; the measured number falls inside the stated range.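

In the Rattus norvegicus assay no new step can be read: compound 2 has no number there, and compound 1 differs from compound 3 in more than one place. In a physicochemical assay for solubility, in simulated intestinal fluid (on this read-out higher numbers stand for higher solubility and lower numbers for lower solubility), compound 2 gives 1 ug/mL and compound 3 gives 14 ug/mL, which is a 14-fold higher number from compound 2 to compound 3 (1.15 log units; beyond the scatter) on this read-out. From the compounds shown here alone, whether losing the (pyridin-3-yl)amino group shifts distribution in the rat stays open.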